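Swapping the ring-nitrogen aryl group: cyclopropylphenyl for tolyl

A few compounds are considered here, and "the series" means these few. Any claim that something is new, unique, unknown or untested is made for them only; others in the source may bear on it.

This account follows one change within a small set of compounds built on the shared core, and begins with compound 1 `Cc1cccc(N2C(=O)CSC2c2cccc(C(=O)NCCCCc3ccccc3)c2)c1`. In an ADME assay on microsomes from liver (Rattus norvegicus) for metabolic stability, read by LC-MS, using NADPH, with a stated time of 10 min, tested at 0.1 uM (a higher number here means faster removal of the compound, a lower number slower removal), compound 1 gives 3140 mL.min-1.g-1, the highest of the two numbers measured, and its nearest neighbour is compound 2 `Cc1ccnc(N2C(=O)CSC2c2cccc(C(=O)NCCCCn3cccn3)c2)c1`, which in this assay gives 1020 mL.min-1.g-1; the gap between the two is beyond the scatter. Compound 3 `O=C(NCCCCc1ccccc1)c1cccc(C2SCC(=O)N2c2ccc(C3CC3)cc2)c1` has not yet been measured in this assay. Its structure departs from compound 1 in one place (4-cyclopropylphenyl in place of 3-methylphenyl on an amide-type nitrogen in a ring), on the amide-type nitrogen in the ring. For the measured compounds named here, no measured pair shows what such a change does here, so the expectation rests on compound 1 alone. Going by the values given here, the step from compound 1 to compound 3 is expected to be small, with no clear direction, since the only change is the group on the amide-type nitrogen in the ring, and the estimate corresponds to a 1.0-fold lower number from compound 1 to compound 3 (0.02 log units; within the scatter). Compound 3 is therefore estimated at 3000 mL.min-1.g-1, with a range from 1400 mL.min-1.g-1 to 6500 mL.min-1.g-1.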

Compound 3, intrinsic clearance in microsomes: 2280 mL.min-1.g-1
For compound 3 the middle estimate is 1.3-fold (0.12 log units) above the measured one; the measured number falls inside the stated range.
By their numbers in this assay, from the lowest: compound 2; then compounds 3 and 1 (each within the scatter of the next).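

In this assay, for the compounds shown here, this step gives the first direct reading of a change on the amide-type nitrogen in the ring: a 1.4-fold lower number from compound 1 to compound 3 (0.14 log units; within the scatter). Placing 4-cyclopropylphenyl where 3-methylphenyl stood therefore leaves the two compounds within the scatter, so this single step shows no measurable effect of the swap on clearance, although the entering group differs both in its substituent and in where that substituent sits on the phenyl ring. Going by these compounds alone, nothing available here explains this outcome, and the single step cannot separate the contributions of those two differences.

The compounds shown leave open whether a phenyl ring carrying an amine or a carboxylic acid on this same nitrogen would move the number beyond the scatter, or whether groups on this nitrogen matter little in this series. They also leave open whether the swap from 3-methylphenyl to 4-cyclopropylphenyl would read the same with a different side chain on the amide of the shared core.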